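This account rests on a few compounds, and the source may have more. Where it says the series, first, only, none or still open, it means among the compounds named here.

Measured so far:
Compound 1 `OC[C@H]1O[C@@H](n2cnc3c(NCc4ccc(F)cc4)ncnc32)[C@H](O)[C@@H]1O`: in a functional assay on MCF cells (Homo sapiens) for antiproliferative activity, with a stated time of 72 h (a higher number here means a weaker inhibitor, a lower number a stronger inhibitor), compound 1 gives 21000 nM.
Compound 2 `COc1ccccc1CNc1ncnc2c1ncn2[C@@H]1O[C@H](CO)[C@@H](O)[C@H]1O`: compound 2 gives only a limit, > 166000 nM, in this assay.

Compound 1 holds the only actual number shown, the other value being a limit. Among the compounds with values here, the one measured step, an at least 7.9-fold higher number from compound 1 to compound 2 (0.89 log units; beyond the scatter), concerns a different exchange and so offers no direct guide. Compound 3 `OC[C@H]1O[C@@H](n2cnc3c(NCc4ccc(F)c(Cl)c4)ncnc32)[C@H](O)[C@@H]1O` differs from compound 1 by chloro in place of hydrogen on an aromatic carbon. Within the data shown here, with no step of this kind measured, the expectation for compound 3 is a change of a 1.4-fold lower number from compound 1 to compound 3 (0.15 log units; within the scatter), staying within the scatter, and its value in this assay is estimated at 15000 nM, between 4000 nM and 60000 nM.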

Compound 3, half-maximal inhibitory concentration: > 166000 nM
Compound 3 was reported as a limit; the forecaster's own chance of this, stated with the estimate: 10%; middle value at least 11-fold (1.04 log units) from the limit.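

Placing a chloro on the aromatic ring, ortho to the fluoro group, is not a neutral change in this assay: the step is an at least 7.9-fold higher number from compound 1 to compound 3 (0.89 log units; beyond the scatter). One added heavy atom on the 4-fluorobenzyl group therefore loses the measurable activity of compound 1, and compound 3 gives only a limit. The full size of this loss cannot be read, and neither can the step between the two limits, because the readings stop at the same point: the limit of > 166000 nM in this assay, at which 2 of the 3 values shown sit.

On these data alone, whether a methyl, a second fluoro or an amine at this same place would behave like chloro remains open.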